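A second chloro on the aryl ring: expectation for compound 4

The source may report more compounds than this note shows. Statements on the series, on what has been measured and on what is new or still open speak of the compounds shown alone.

Compound 1 `Cc1nc2c([nH]1)C(=O)/C(=N/c1ccccc1)C(Cl)=C2O` is measured in an ADME assay (Rattus norvegicus) for inhibition (a lower number here means a stronger inhibitor, a higher number a weaker inhibitor), and gives 800 nM. Compound 2 `Cc1nc2c([nH]1)C(=O)/C(=N/c1cccc(Cl)c1)C(Cl)=C2O` carries one change, (chloro in place of hydrogen on an aromatic carbon), and in this assay compound 2 gives 900 nM; the step of a 1.1-fold higher number from compound 1 to compound 2 (0.05 log units; within the scatter) is small. Compound 3 `Cc1nc2c(nc1C)C(=O)C(Nc1ccc(Cl)cc1)=CC2=O` rests on a different core; the difference between the two cores is not broken down here. In this assay compound 3 gives 3300 nM. Compound 4 `Cc1nc2c(nc1C)C(=O)C(Nc1ccc(Cl)c(Cl)c1)=CC2=O` is not yet measured and differs from compound 3 by chloro in place of hydrogen on an aromatic carbon. Among the measured compounds shown here, this is the same kind of change as the one from compound 1 to compound 2, but here the place is also ortho to a chloro group. Because the step of a 1.1-fold higher number from compound 1 to compound 2 (0.05 log units; within the scatter) stayed within the scatter, a similarly small step is expected from compound 3 to compound 4, namely a 1.1-fold higher number from compound 3 to compound 4 (0.03 log units; within the scatter). For compound 4 in this assay the estimate is 3500 nM, between 1800 nM and 7000 nM.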

Compound 4, half-maximal inhibitory concentration: 3800 nM
Compound 4: middle estimate off by 1.1-fold (0.04 log units), on the low side, and the stated range covers the measured number.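

In this assay, putting chloro in place of hydrogen on the aryl ring gives a 1.2-fold higher number from compound 3 to compound 4 (0.06 log units; within the scatter), so on this second core the change again makes no readable difference. The two steps agree closely: the same change on two cores in this assay, a 1.1-fold higher number (0.05 log units; within the scatter) from compound 1 to compound 2 and a 1.2-fold higher number (0.06 log units; within the scatter) from compound 3 to compound 4, 1.0-fold (0.01 log units) apart, within the scatter of two such steps. This shows that, in these two pairs, the change carries from one core to the other as a step too small to read, even with the new chloro ortho to a chloro group; it does not show that the same would hold on other cores, or that a larger step would carry over in the same way.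

The compounds shown leave open whether another group on the aryl ring, such as an amine or a carboxylic acid, would give a step beyond the scatter on either core. They also leave open how the two cores compare by themselves.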